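A few compounds are considered here, and "the series" means these few. Any claim that something is new, unique, unknown or untested is made for them only; others in the source may bear on it.

Compound 1 `COc1cc(/C=N/NC(=O)CCCc2nc3ccccc3c(=O)[nH]2)cc(OC)c1OC`: 60000000 nM
Compound 2 `COc1cc(/C=N/NC(=O)CCCc2nc3ccccc3c(=O)[nH]2)ccc1O`: 115000000 nM

In a physicochemical assay, read by spectrophotometry, with a stated time of 6 min (a higher number here means a weaker inhibitor, a lower number a stronger inhibitor), compound 1 at 60000000 nM and compound 2 at 115000000 nM lie within the usual scatter of each other, so these two values do not separate the compounds. Within the data shown here, compound 2 therefore stands level with the only other measured compound, and that is the starting point for the next step.

Compound 3 `COc1cc(/C=N/NC(=O)CCCc2nc3ccccc3c(=O)[nH]2)cc(OC)c1O` is compound 2 with methoxy in place of hydrogen on an aromatic carbon. The new methoxy is ortho to a hydroxy group. Among the measured compounds shown here, no measured pair shows what a single change of this kind does, so the only guide is the narrow span of the two values. No step beyond the scatter is expected in this assay.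

The estimated change is a 1.8-fold lower number from compound 2 to compound 3 (0.25 log units; within the scatter). For compound 3 the expected value is 65000000 nM, with an estimated range of 25000000 nM to 170000000 nM.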

Compound 3, half-maximal inhibitory concentration: 135000000 nM
Beside the measured number, compound 3's estimate is 2.1-fold (0.32 log units) below it; the measured number falls inside the stated range.
By their numbers in this assay, from the lowest: compounds 1, 2 and 3 (each within the scatter of the next, the first and the last beyond it).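

In this assay, methoxy in place of hydrogen on an aromatic carbon, ortho to a hydroxy group, gives a 1.2-fold higher number from compound 2 to compound 3 (0.07 log units; within the scatter) and so leaves compound 2 and compound 3 level at this position. The other single change, hydrogen in place of methyl on an oxygen on an aromatic ring, gives a 2.3-fold higher number from compound 1 to compound 3 (0.35 log units; beyond the scatter) as a modest step beyond the scatter, which shows that this oxygen's methyl group counts for more here than the added methoxy does. Nothing measured here explains either result.

The compounds shown carry only hydroxy and methoxy groups on this ring, so it remains open what an amine or a carboxylic acid would do at these positions. Going by these compounds, the effect of a longer chain between this ring and the shared core also remains open.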